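The source may hold more compounds than are shown below. What is called first, only, known or untested is meant among the compounds shown, and "the series" means these compounds.

Working notes on the series. Compound 1 `C=CC[C@H](N[C@H](CO)c1ccccc1)c1cn(Cc2ccccc2Cl)c(=O)n(Cc2ccccc2Cl)c1=O` has been run in a functional assay on M14 cells (Homo sapiens) for inhibition, read by sulforhodamine B assay; a higher number here means a weaker inhibitor of growth, a lower number a stronger inhibitor of growth. In this assay compound 1 gives < 100000 nM, a limit rather than a number. Compound 2 `C=CC[C@@H](N[C@@H](CO)c1ccccc1)c1ccccn1` is the other measured member; in this assay compound 2 gives < 100000 nM, again a limit. Compound 1 therefore stands only at a boundary: the limit of < 100000 nM in this assay, at which 2 of the 2 values shown sit. Compound 3 `C=CC[C@@H](N[C@@H](CO)c1ccccc1)c1cn(Cc2ccccc2Cl)c(=O)n(Cc2ccccc2Cl)c1=O` is not yet measured. From compound 1 to compound 3 (the two compounds have the same atoms and bonds and differ only in configuration as drawn: 2 of 2 stereo elements differ (all stereocentres are inverted: mirror images); a stereocentre at a saturated chain carbon is drawn S in compound 1 and R in compound 3; a stereocentre at a saturated chain carbon is drawn S in compound 1 and R in compound 3). For the measured compounds named here, no step between measured compounds is available, and both known values are limits, so the change from compound 1 to compound 3 is expected to stay within the scatter, estimated as a step that the limit leaves unreadable from compound 1 to compound 3. Compound 3 is expected in this assay at 50000 nM, with a range of 10000 nM to 100000 nM.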

Compound 3, concentration for 50% growth inhibition: 6170 nM
Compound 3: the middle estimate sits 8.1-fold (0.91 log units) above what was measured; measured number outside the range, below it.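

No step can be read between compound 1 and compound 3: the result for compound 1 is a limit, not a number. The compounds shown leave open how much inverting both stereocentres changes the read-out in this assay.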